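The source may hold more compounds than are shown below. What is called first, only, known or untested is meant among the compounds shown, and "the series" means these compounds.

In a toxicity assay on cells (Fibroblast, Homo sapiens) for cytotoxicity (a lower number here means a stronger inhibitor, a higher number a weaker inhibitor), compound 3 `CC(/C=C/C1=CCCCC1(C)C)=C\C=C\C(C)=C\COC(=O)c1c(O)cccc1O` gives 14000 nM, the lowest number of the three measured, ahead of compound 1 `CC(/C=C/C1=CCCCC1(C)C)=C\C=C\C(C)=C\COC(=O)c1cc(O)c(O)c(O)c1` at 35000 nM and compound 2 `CC(/C=C/C1=CCCCC1(C)C)=C\C=C\C(C)=C\COC(=O)c1ccccc1O` at 150000 nM. Compound 4 `COc1cc(O)c(C(=O)OC/C=C(C)/C=C/C=C(C)/C=C/C2=CCCCC2(C)C)c(O)c1` keeps everything in compound 3 and adds (methoxy in place of hydrogen on an aromatic carbon), methoxy in place of hydrogen on an aromatic carbon. For the measured compounds named here, no measured step adds a methoxy, so the guidance is indirect. Adding one hydroxy produced a large change, an 11-fold lower number from compound 2 to compound 3 (1.03 log units; beyond the scatter), and the different hydroxy pattern produced a modest one, a 2.5-fold lower number from compound 1 to compound 3 (0.40 log units; beyond the scatter). Compound 4 retains both hydroxy groups of compound 3, so only a small change is expected. The expected step is a 1.4-fold higher number from compound 3 to compound 4 (0.15 log units; within the scatter), a slight rise that stays within the scatter. For compound 4 the estimated value is 20000 nM, with an expected range of 8000 nM to 50000 nM.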

Compound 4, half-maximal inhibitory concentration: 14000 nM
For compound 4 the middle estimate is 1.4-fold (0.15 log units) above the measured one; low and high end bracket the measured number.
By their numbers in this assay, from the lowest: compounds 3 and 4 (each within the scatter of the next); then compound 1; then compound 2.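

Placing a methoxy on this aromatic carbon, meta to two hydroxy groups and para to a large group, leaves the number in this assay where it was (no change at the digits printed from compound 3 to compound 4 (within the scatter)), so this position takes the added group without a visible effect. Compound 4 therefore keeps the same lead as compound 3 over the others (an 11-fold lower number from compound 2 to compound 4 (1.03 log units; beyond the scatter); a 2.5-fold lower number from compound 1 to compound 4 (0.40 log units; beyond the scatter)). Nothing available explains this lack of effect. On these data alone, whether an amine or a longer chain such as butoxy would be tolerated here remains open. So does whether a methoxy at this position would behave the same way with only one hydroxy on the ring, as in compound 2.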